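The compounds below may be only part of what the source reports. "The series", "measured", "known", "first", "only" and "open" are said of these compounds alone.

Measured in a physicochemical assay for lipophilicity; on this read-out higher numbers stand for higher lipophilicity and lower numbers for lower lipophilicity:
compound 1 `Cc1ccc(Oc2cc(C(O)CC3CCCCN3)c3ccccc3n2)cc1`: 2.69
compound 2 `Cc1ccc(Oc2cc(C(O)CC3CCCCN3)c3cc(Cl)ccc3n2)cc1`: 3.4
compound 3 `COc1ccc2nccc(C(O)CC3CCC(/C=C/Br)CN3)c2c1`: 1.71

Compound 1 stands second highest of the three numbers in this assay; the nearest value is that of compound 2, a step of a number 0.71 log units higher from compound 1 to compound 2 (beyond the scatter), and the furthest is that of compound 3, which is the lowest of the three.

Compound 4 `OC(CC1CCCCN1)c1cc(C2CCCCC2)nc2ccccc12` differs from compound 1 in one place: cyclohexyl in place of 4-methylphenoxy on an aromatic carbon. Going by the values given here, the one measured step, a number 0.71 log units higher from compound 1 to compound 2 (beyond the scatter), concerns chloro in place of hydrogen and does not bear on cyclohexyl in place of 4-methylphenoxy; no measured pair shows that exchange. The expectation therefore rests on compound 1 alone. A modest rise is expected, a number 0.31 log units higher from compound 1 to compound 4 (beyond the scatter), though a step within the scatter cannot be excluded. Compound 4 is estimated at 3 in this assay, with a range of 2.4 to 3.6.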

Compound 4, partition coefficient: 2.56
The estimate for compound 4 lay 0.44 log units above the measured number; the measured number falls inside the stated range.
By their numbers in this assay, from the lowest: compound 3; then compounds 4 and 1 (each within the scatter of the next); then compound 2.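

In this assay, cyclohexyl in place of 4-methylphenoxy on the aromatic carbon next to the ring nitrogen gives a number 0.13 log units lower from compound 1 to compound 4 (within the scatter). Going by these compounds alone, this position therefore takes a non-aromatic carbon ring in place of an aromatic ring carrying a hydrogen-bond acceptor with no step beyond the scatter, whereas the only earlier step concerned chloro at another place on the core. Nothing on hand explains why these two groups read alike.

On these data alone, whether an amine or a carboxylic acid at this position would stay within the scatter remains open. So does whether chloro on compound 4 would repeat a number 0.71 log units higher from compound 1 to compound 2 (beyond the scatter).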